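The compounds below may be only part of what the source reports. "The series", "measured", "known", "first", "only" and "open" are said of these compounds alone.

Measured compounds:
compound 1 `CCC(=O)Nc1cccc(Oc2nc(Nc3ccc(N(C)C)cc3)ncc2Cl)c1` — 72.6%
compound 2 `CCC(=O)Nc1cccc(Oc2nc(Nc3ccc(N4CCC(OC)CC4)cc3OC)ncc2Cl)c1` — 5.08%
compound 3 `CCC(=O)Nc1cccc(Oc2nc(Nc3ccc(N4CCC(C)CC4)cc3)ncc2Cl)c1` — 13.4%

In an assay on isolated protein for inhibition of NUAK family SNF1-like kinase 1 (Homo sapiens), read by ADP-Glo, with a stated time of 60 min, tested at 10 uM, in the presence of a further agent that is not named here (on this read-out lower numbers stand for less inhibition and higher numbers for more inhibition at the one concentration tested (going by the name of the read-out)), compound 3 sits second highest of the three numbers: compound 2 lies within the scatter of it, while compound 1 lies well beyond, a number 59.2 percentage points lower from compound 1 to compound 3 (beyond the scatter).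

Compound 4 `CCC(=O)Nc1cccc(Oc2nc(Nc3ccc(N4CCC(OC)CC4)cc3)ncc2Cl)c1` is the unmeasured partner of compound 3. The change is methoxy in place of methyl on a saturated ring carbon, that is, 4-methylpiperidin-1-yl to 4-methoxypiperidin-1-yl.

Within the data shown here, only one measured step bears on this, and indirectly: the exchange of dimethylamino for 4-methylpiperidin-1-yl gave the large drop a number 59.2 percentage points lower from compound 1 to compound 3 (beyond the scatter). Among the measured compounds shown here, compound 2, which carries the 4-methoxypiperidin-1-yl group together with a further methoxy, gives a number within the scatter of compound 3; no single-point step between compound 2 and compound 4 exists, so that pair can only be read by its two values. Nothing here suggests that a methoxy in place of methyl on the saturated ring carbon changes the read-out beyond the scatter.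

For compound 4 the expected step is therefore a number 3.4 percentage points lower from compound 3 to compound 4 (within the scatter), no change beyond the scatter. Compound 4 is estimated at 10%, in the range 0% to 28%.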

Compound 4, a percentage reported as inhibition, at one concentration (the size of the read-out at that concentration, not a potency): 86.5%
Beside the measured number, compound 4's estimate is 76.5 percentage points below it; the measured number lies above the stated range.
By their numbers in this assay, from the lowest: compounds 2 and 3 (each within the scatter of the next); then compound 1; then compound 4.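

In this assay the group on the saturated ring carbon, three ring bonds from the ring nitrogen, decides the read-out: methoxy in place of methyl gives a number 73.1 percentage points higher from compound 3 to compound 4 (beyond the scatter), so the low number of compound 3 does not hold for the piperidine ring as such. The 4-methoxypiperidin-1-yl group also surpasses dimethylamino, with a number 13.9 percentage points higher from compound 1 to compound 4 (beyond the scatter), yet this high number depends on the aromatic carbon that differs in compound 2, where hydrogen in place of methoxy gives a number 81.4 percentage points higher from compound 2 to compound 4 (beyond the scatter). Nothing available explains either large step.

Open, on these data alone, is whether a hydroxyl, an amine or a longer chain such as ethoxy on the same saturated ring carbon would match methoxy. Also open, as far as these compounds go, is whether a fluorine or a methyl on that aromatic carbon would cost as much as methoxy.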